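The source may report more compounds than this note shows. Statements on the series, on what has been measured and on what is new or still open speak of the compounds shown alone.

Series notes. Compound 1 `O=C1OC(c2cc(O)cc(O)c2)C(c2ccc(O)cc2)=C1O`, compound 2 `O=C1OC(c2ccc(O)cc2)C(c2ccc(O)cc2)=C1O` and compound 3 `O=C1OC(c2ccc(O)cc2)C(c2ccc(F)cc2)=C1O` have been run in an assay on blood for inhibition of Polyunsaturated fatty acid 5-lipoxygenase (Homo sapiens), tested at 100 uM; on this read-out higher numbers stand for a stronger effect at the one concentration tested and lower numbers for a weaker effect. Compound 1 gives 11.6%, compound 2 gives 27.8% and compound 3 gives 0%. The cores of compound 1 and compound 2 differ, but that difference is not broken down here. Compound 2 and compound 3 are linked by a single change, (fluoro in place of hydroxy on an aromatic carbon), which in this assay reads a number 27.8 percentage points lower from compound 2 to compound 3 (beyond the scatter). Compound 4 `O=C1OC(c2cc(O)cc(O)c2)C(c2ccc(F)cc2)=C1O` has not yet been measured; it stands to compound 1 as compound 3 stands to compound 2, through (fluoro in place of hydroxy on an aromatic carbon). Among the compounds with values here, the two changes are the same, at the same place, so the earlier step is the only guide. Compound 1 starts from 11.6%, so a step of the earlier size cannot be repeated in full: the read-out cannot fall further than to nothing. In this assay the step expected here is a number 10.6 percentage points lower from compound 1 to compound 4 (beyond the scatter), resting on a number 27.8 percentage points lower from compound 2 to compound 3 (beyond the scatter) and on compound 1 already sitting at 11.6%. For compound 4 the estimate is 1%, between 0% and 12%.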

Compound 4, a percentage reported as activity, at one concentration (the size of the read-out at that concentration, not a potency): 10.7%
Estimate against measurement, compound 4: 9.7 percentage points below; the range from low to high includes it.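

In this assay, the change from 4-hydroxyphenyl to 4-fluorophenyl on the core of compound 1 reads a number 0.9 percentage points lower from compound 1 to compound 4 (within the scatter). The same change does not carry over as a fixed step between the two cores, and its size differs with the core in the two pairs available: the same change on two cores in this assay, a number 27.8 percentage points lower (beyond the scatter) from compound 2 to compound 3 and a number 0.9 percentage points lower (within the scatter) from compound 1 to compound 4, 26.9 percentage points apart, beyond the scatter of two such steps This shows that the loss seen on the core of compound 2 does not transfer to the core of compound 1, but it does not show which feature of the cores sets the difference, and two pairs give no rule for any other core.

The compounds shown leave open how a methoxy group, a chlorine atom or an amine at this place, on an aromatic carbon para to a large group, would read on either core. Also open, going by these compounds, is whether the effect at the one concentration tested would read the same at other concentrations, which a full concentration series on compound 1 and compound 4 could address.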